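The source may hold more compounds than are shown below. What is called first, only, known or untested is meant among the compounds shown, and "the series" means these compounds.

Measured compounds:
Compound 1 `COc1cc(O)c(C(=O)/C=C/c2ccc(F)cc2)c(OC)c1`, in a functional assay on MDA-MB-231 cells (Homo sapiens), read by fluorescence and BrdU incorporation, with a stated time of 48 h, tested at 10 uM (on this read-out lower numbers stand for a stronger effect and higher numbers for a weaker effect at the one concentration tested), compound 1 gives "not active" (no number reported).
Compound 2 `COc1cc(OC)c(C(=O)/C=C/c2ccc(Cl)cc2)c(OC)c1`, in this assay compound 2 gives 39%.
Compound 3 `COc1cccc(/C=C/C(=O)c2c(O)cc(OC)cc2OC)c1`, in this assay compound 3 gives 54%.

Among the two entries that carry a number in this assay, compound 2 stands lowest, which on this read-out is the stronger effect; the nearest entry is compound 3, whose number lies higher by a gap beyond the usual scatter, while compound 1 contributes no single number. Going by the values given here, no step between two measured compounds that differ in only one place is available, so the step from compound 2 to compound 4 cannot be read off any measured pair.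

Compound 4 `COc1cc(OC)c(C(=O)/C=C/c2ccccc2SC)c(OC)c1` is yet to be measured in this assay. It differs from compound 2 in one place: 2-(methylsulfanyl)phenyl in place of 4-chlorophenyl on a double-bonded chain carbon bound to a double-bonded chain carbon. Because the data hold no comparable change, the size of this step is open; a shift of moderate size in either direction, or none beyond the scatter, remains possible, and the direction is not predictable from the three measured compounds alone.

On that basis compound 4 is expected to give about 50% in this assay, within a range from 30% to 75%. The step this implies, a number 11 percentage points higher from compound 2 to compound 4 (beyond the scatter), is an estimate, not a measurement.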

Compound 4, a percentage reported as activity, at one concentration (the size of the read-out at that concentration, not a potency): 48%
The estimate for compound 4 lay 2 percentage points above the measured number, and the stated range covers the measured number.
By their numbers in this assay, from the lowest: compounds 2, 4 and 3 (each within the scatter of the next, the first and the last beyond it).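

In this assay, putting 2-(methylsulfanyl)phenyl in place of 4-chlorophenyl on a double-bonded chain carbon bound to a double-bonded chain carbon gives a number 9 percentage points higher from compound 2 to compound 4 (within the scatter), so the read-out does not separate the two compounds. Going by these compounds alone, this is the first view of this position that a one-place comparison allows, and it shows that the read-out stays within the scatter even though the group exchanged is not a close match: chlorine leaves and sulfur enters, 8 heavy atoms replace 7, and 1 hydrogen-bond acceptor enters where the departing group has 0.

No further step can be read, since compound 1 and compound 3 each differ from compound 2 and compound 4 in more than one place. On these data alone, whether a phenyl group carrying an amine or a carboxylic acid in this place would also stay within the scatter of compound 2 remains open, as does the outcome for a longer chain in place of the methylsulfanyl group. No measurement shown here accounts for this result.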